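The compounds below may be only part of what the source reports. "The series", "measured", "known", "first", "only" and "open" are said of these compounds alone.

Compound 1, `CC(C)C(c1ccc(-c2ccc3cccc(F)c3c2)[nH]c1=O)N1CCCCS1(=O)=O`, gives 0.373 h in an ADME assay on microsomes from liver (Homo sapiens) for metabolic stability; a lower number here means that the compound disappears faster, a higher number that the compound lasts longer. Compound 3, `CC(C)[C@H](C[C@H]1CCNC1=O)c1ccc(-c2ccc3cccc(F)c3c2)[nH]c1=O`, gives 0.257 h in this assay. Compound 2, `CCn1ncc2c(F)cc(-c3ccc(C(CC)(CC)c4nnc(C)[nH]4)c(=O)[nH]3)cc21`, gives > 3 h in this assay, which is a limit of the assay and not a number.

Going by the values given here, only two numbers are therefore known, and compound 1 and compound 3 lie within the usual scatter of each other, so neither can be called the more stable of the two. The reading for compound 2 is a limit, (the limit of > 3 h in this assay, at which 1 of the 3 values shown sits), and does not yield a step to either of them. Among the compounds with values here, no pair of measured compounds differs in a single place, so no measured step is available to lean on.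

The unmeasured compound 4, `CC(C)C(c1cnc(N)s1)c1ccc(-c2ccc3cccc(F)c3c2)[nH]c1=O`, is reached from compound 1 by the change (a group of 6 heavy atoms (3 carbon, 2 nitrogen, 1 sulfur; one five-membered aromatic ring with 2 hetero atoms) in place of a group of 8 heavy atoms (4 carbon, 1 nitrogen, 2 oxygen, 1 sulfur; one six-membered non-aromatic ring with 2 hetero atoms), on a saturated chain carbon bound to an aromatic carbon and a saturated chain carbon). Within the data shown here, nothing among the measured compounds tracks a change of this kind, so the expectation rests on compound 1 alone. The expected step of a 1.1-fold lower number from compound 1 to compound 4 (0.03 log units; within the scatter) is none beyond the scatter, in no particular direction. Compound 4 is therefore estimated at 0.35 h, with a range from 0.15 h to 0.9 h.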

Compound 4, half-life: 0.178 h
For compound 4 the middle estimate is 2.0-fold (0.29 log units) above the measured one; low and high end bracket the measured number.
By their numbers in this assay, from the lowest: compounds 4, 3 and 1 (each within the scatter of the next, the first and the last beyond it). At a limit, above all of these: compound 2.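

In this assay, going by these compounds alone, putting 2-amino-1,3-thiazol-5-yl in place of the six-membered non-aromatic ring with 2 hetero atoms, on a saturated chain carbon bound to an aromatic carbon and a saturated chain carbon, gives a 2.1-fold lower number from compound 1 to compound 4 (0.32 log units; beyond the scatter) and so provides the first measured step at this place, showing that the half-life in human liver microsomes can respond to the group held there, though only modestly. The step is small enough that compound 3, with its own different group at this carbon, gives 0.257 h and still lies within the scatter of both compound 1 and compound 4, so the three compounds remain a close set in which only the two end members are separated. Nothing in the data shown accounts for the step.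

The compounds shown leave open whether the amino group of the thiazole or the ring itself goes with the step, which a plain thiazole or a phenyl ring at this carbon would help to separate. They also leave open whether a carboxylic acid or an open-chain sulfonamide at this carbon would give a number of a different order.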